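A few compounds are considered here, and "the series" means these few. Any claim that something is new, unique, unknown or untested is made for them only; others in the source may bear on it.

Measured in an assay on isolated protein for binding affinity to leukotriene B4 receptor 1 (Homo sapiens), tested at 1 uM; a lower number here means less inhibition, a higher number more inhibition at the concentration tested (going by the name of the read-out):
compound 1 `C=CCc1cc(C(C)=O)c(O)cc1OCCCCCCCCC#N`: 50%
compound 2 `C=CCc1cc(C(C)=O)c(O)cc1OCCCCCCCCCCC#N`: 14%
compound 3 `C=CCc1cc(C(C)=O)c(O)cc1OCCCCO`: 9%

Compound 3 stands at the low end of these three numbers: against compound 1 the step of a number 41 percentage points lower from compound 1 to compound 3 (beyond the scatter) is large, while against compound 2 the step of a number 5 percentage points lower from compound 2 to compound 3 (within the scatter) is within the scatter. Compound 4 `C=CCc1cc(C(C)=O)c(O)cc1OCCCCCC(=O)NO` has not yet been measured; the change is (hydroxycarbamoyl)methyl in place of hydroxy on a saturated chain carbon, four bonds along the chain from an oxygen on an aromatic ring. The two measured steps at this same place on the chain both exchange a chain ending in a nitrile for a hydroxy, and they disagree in size, one large and one within the scatter, so a longer group in place of the hydroxy may or may not raise the reading. A modest rise is therefore expected, with wide bounds, a number 11 percentage points higher from compound 3 to compound 4 (beyond the scatter). Compound 4 is estimated at 20%, between 5% and 45%.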

Compound 4, a percentage reported as inhibition, at one concentration (the size of the read-out at that concentration, not a potency): 28%
For compound 4 the middle estimate is 8 percentage points below the measured one, within the range that was stated.
By their numbers in this assay, from the lowest: compounds 3 and 2 (each within the scatter of the next); then compound 4; then compound 1.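

The change gives a number 19 percentage points higher from compound 3 to compound 4 (beyond the scatter) in this assay and so shows that a chain end other than a nitrile can also lift the reading above that of the hydroxy. The hydroxycarbamoyl end falls short of the shorter nitrile chain, with a number 22 percentage points lower from compound 1 to compound 4 (beyond the scatter) and yet clears the longer one, with a number 14 percentage points higher from compound 2 to compound 4 (beyond the scatter) and so sits among the nitriles rather than at either end. Nothing given here accounts for these differences. From the compounds shown here alone, whether a carboxylic acid or an amine at the chain end would read like hydroxycarbamoyl stays open, as does how a longer chain carrying hydroxycarbamoyl would read.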